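Swapping the Dimethoxyphenyl on Sulfur for Phenethyl

The source may hold more compounds than are shown below. What is called first, only, known or untested is meant among the compounds shown, and "the series" means these compounds.

Of the compounds shown here, three sharing a common core have been tested in a functional assay on SMMC-7721 cells (Homo sapiens) for inhibition, read by CCK-8 assay, with a stated time of 72 h, tested at 2 uM; a higher number here means more inhibition of growth at the concentration tested, a lower number less inhibition of growth. Compound 1 `COc1ccc(SCc2ccc(/C=C/C(=O)Nc3ccccc3N)cc2)cc1OC` gives 14.3%, the lowest of the three numbers. Compound 2 `COc1ccc(SCc2ccc(C(=O)Nc3ccccc3N)cc2)cc1` gives 33.1%, beyond the usual scatter above compound 1, and compound 3 `Nc1ccccc1NC(=O)c1ccc(CSc2nccc(C(F)(F)F)n2)cc1` gives 66.1%, the furthest above compound 1. Compound 4 `Nc1ccccc1NC(=O)/C=C/c1ccc(CSCCc2ccccc2)cc1` has not been measured yet. It keeps the core of compound 1 and differs from it in one place: phenethyl in place of 3,4-dimethoxyphenyl on a sulfur. For the measured compounds named here, no measured pair shows this particular exchange, so its effect is not known from the data. The step from compound 1 to compound 4 is expected to be small, possibly a slight rise, but likely within the scatter: a number 9.7 percentage points higher from compound 1 to compound 4 (within the scatter). Compound 4 is therefore estimated at 24%, within a range from 8% to 45%.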

Compound 4, percent growth inhibition at one concentration: 14.7%
Beside the measured number, compound 4's estimate is 9.3 percentage points above it; low and high end bracket the measured number.
By their numbers in this assay, from the lowest: compounds 1 and 4 (each within the scatter of the next); then compound 2; then compound 3.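

Phenethyl in place of 3,4-dimethoxyphenyl on a sulfur gives, in this assay, a number 0.4 percentage points higher from compound 1 to compound 4 (within the scatter). This exchange removes both hydrogen-bond acceptors of the leaving group and puts a saturated chain on the sulfur, yet the two compounds cannot be told apart at this single concentration. No supporting data explain this outcome. Still open, going by these compounds, is whether any group on this sulfur can move the number on this core. A longer chain, or a phenethyl carrying an amine or a carboxylic acid, would test that.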